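A few compounds are considered here, and "the series" means these few. Any claim that something is new, unique, unknown or untested is made for them only; others in the source may bear on it.

Compound 2 `Nc1ncc(-c2ccc(C(=O)N3CCC(O)CC3)cc2)nc1-c1ccc(C(F)(F)F)cc1` gives the lowest number of the three compounds measured in a physicochemical assay for solubility, read by HPLC, using the shake flask method, in phosphate buffer, with a stated time of 2 h, at pH 6.5; a lower number here means a less soluble compound, a higher number a more soluble compound: compound 2 gives 19000 nM, while compound 1 `Nc1ncc(-c2ccc(C(=O)O)cc2)nc1-c1ccc(C(F)(F)F)cc1` gives 95000 nM and compound 3 `CNC(=O)c1ccc(-c2nc(-c3ccc(C(N)=O)cc3)cnc2N)cc1` gives 178000 nM. Among the measured compounds shown here, the only step measured so far is a 5.0-fold lower number from compound 1 to compound 2 (0.70 log units; beyond the scatter), a change at the carbonyl carbon of a different kind from the one now considered. Compound 4 `Nc1ncc(-c2ccc(C(=O)N3CCC(O)C3)cc2)nc1-c1ccc(C(F)(F)F)cc1` differs from compound 2 by 3-hydroxypyrrolidin-1-yl in place of 4-hydroxypiperidin-1-yl on a carbonyl carbon, a five-membered ring in place of a six-membered one. For the measured compounds named here, no measured step shows what such a ring change does here, so a step no larger than the scatter is expected, a 1.3-fold higher number from compound 2 to compound 4 (0.12 log units; within the scatter). Compound 4 is therefore expected to give 25000 nM, within a range of 10000 nM to 60000 nM.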

Compound 4, solubility: 77000 nM
The estimate for compound 4 lay 3.1-fold (0.49 log units) below the measured number; the measured number lies above the stated range.
By their numbers in this assay, from the lowest: compound 2; then compounds 4, 1 and 3 (each within the scatter of the next, the first and the last beyond it).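

At the carbonyl carbon, the ring on the amide clearly matters: in this assay, 3-hydroxypyrrolidin-1-yl in place of 4-hydroxypiperidin-1-yl gives a 4.1-fold higher number from compound 2 to compound 4 (0.61 log units; beyond the scatter), so this small ring change is not silent. The drop seen with 4-hydroxypiperidin-1-yl is also not shared by every amide here, as replacing hydroxy with 3-hydroxypyrrolidin-1-yl gives a 1.2-fold lower number from compound 1 to compound 4 (0.09 log units; within the scatter), with the gap staying inside the scatter. No measurement shown here explains the difference between the two rings.

Compound 2 and compound 4 differ in both ring size and where the hydroxy group sits, so these two effects cannot yet be separated. On these data alone, a 3-hydroxypiperidin-1-yl group on the same carbonyl carbon could separate them, while the effect of an open-chain amine there remains unknown.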